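A few compounds are considered here, and "the series" means these few. Any claim that something is new, unique, unknown or untested is made for them only; others in the source may bear on it.

Compound 1 `Cc1c(OCCCCOc2ccc(C(=O)O)cc2)ccc(C(=O)CC2CCCC2)c1O` in an assay on HEK293 cells for positive allosteric modulation of metabotropic glutamate receptor 3 (Rattus norvegicus), read by thallium flux, with a stated time of 2.5 min (on this read-out lower numbers stand for an effect already at smaller amounts and higher numbers for an effect only at larger amounts of compound), gives > 10000 nM, which is a limit of the assay rather than a number. Compound 2 `Cc1cc(C(=O)O)ccc1OCCCCOc1ccc(C(=O)CC2CCCC2)c(O)c1C` gives > 10000 nM, again a limit. Compound 3 `CC(=O)c1ccc(OCCCCOc2ccc(F)c(C(=O)O)c2)c(C)c1O` gives "not determined" (no result reported).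

Going by the values given here, compound 3 therefore stands without a number of its own; the two other values shown are limits, as the limit of > 10000 nM in this assay, at which 2 of the 3 values shown sit, records, and the only step between measured compounds, a step that the two limits leave unreadable from compound 1 to compound 2, is unreadable for the same reason. Compound 4 `Cc1c(OCCCCOc2ccc(F)c(C(=O)O)c2)ccc(C(=O)CC2CCCC2)c1O` differs from compound 3 in one place: cyclopentyl in place of hydrogen on a saturated chain carbon bound to a carbonyl carbon. Among the compounds with values here, no measured step follows this change, so neither its size nor its direction can be read. Compounds 1 and 2, which also carry the cyclopentylmethyl group, both sit at the limit of > 10000 nM in this assay, at which 2 of the 3 values shown sit. Compound 4 is thus expected to give about 15000 nM (range 3000 nM to 50000 nM), with a fair chance that only a limit is reported.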

Compound 4, half-maximal effective concentration: 2490 nM
Compound 4: middle estimate off by 6.0-fold (0.78 log units), on the high side; measured number below the stated range.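

In this assay, 3-carboxy-4-fluorophenyl in place of 4-carboxy-2-methylphenyl on the oxygen gives an at least 4.0-fold lower number from compound 2 to compound 4 (0.60 log units; beyond the scatter). In place of 4-carboxyphenyl it gives an at least 4.0-fold lower number from compound 1 to compound 4 (0.60 log units; beyond the scatter), so this group on the oxygen can move the read-out. Going by these compounds alone, compound 4 is the first compound here with a number rather than a limit: the limit of > 10000 nM in this assay, at which 2 of the 4 values shown sit.

With no result for compound 3, the effect of cyclopentyl on the saturated chain carbon cannot be read, nor can the step between the two limits. From the compounds shown here alone, how the carboxylic acid's place and the fluorine share the gain stays open, and a plain 3-carboxyphenyl group would separate them.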